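A few compounds are considered here, and "the series" means these few. Any claim that something is new, unique, unknown or untested is made for them only; others in the source may bear on it.

Going by the values given here, in a physicochemical assay for solubility, in phosphate buffer, at pH 6.5 (on this read-out lower numbers stand for lower solubility and higher numbers for higher solubility), compound 2 (`CCOc1cc(CN2CCC(NC(=O)c3cncc(C)c3)CC2)cc(OCC)c1Cl`) gives 216 ug/mL, the higher of the two numbers so far, while compound 1 (`CCOc1cc(CN2CCC(NC(=O)c3cncc(C)c3)CC2)cc(OCC)c1-c1ccc(F)cc1`) gives 94 ug/mL. Compound 3 (`CCOc1cc(CN2CCC(NC(=O)c3cncc(C)c3)CC2)cc(OCC)c1-c1ccc(OC(F)(F)F)cc1`) carries 4-(trifluoromethoxy)phenyl in place of chloro on an aromatic carbon, ortho to two ethoxy groups: 4-(trifluoromethoxy)phenyl in place of chloro on an aromatic carbon. Among the compounds with values here, one measured step bears on this change, and it runs the reverse way: chloro in place of 4-fluorophenyl gave a 2.3-fold higher number from compound 1 to compound 2 (0.36 log units; beyond the scatter), a modest step beyond the scatter. Read backwards, that step points to a lower number in this assay, of similar or somewhat larger size. Within the data shown here, no compound yet measured carries 4-(trifluoromethoxy)phenyl, so the size remains uncertain. The expected change is a 3.6-fold lower number from compound 2 to compound 3 (0.56 log units; beyond the scatter). Compound 3 is estimated at 60 ug/mL, with an expected range from 20 ug/mL to 130 ug/mL.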

Compound 3, solubility: < 1 ug/mL
Compound 3 gave a limit, no number; the forecaster's own chance of this, stated with the estimate: 5%; middle value at least 60-fold (1.77 log units) away from the limit.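

In this assay, compound 3 gives a limit of the assay and not a number: the limit of < 1 ug/mL in this assay, at which 1 of the 3 values shown sits. Replacing chloro with 4-(trifluoromethoxy)phenyl on this aromatic carbon, ortho to two ethoxy groups, gives an at least 210-fold lower number from compound 2 to compound 3 (2.33 log units; beyond the scatter), far more than the one earlier step at this position had shown. Trifluoromethoxy in place of fluoro on the added phenyl ring gives an at least 94-fold lower number from compound 1 to compound 3 (1.97 log units; beyond the scatter), so the read-out here depends heavily on what that phenyl ring carries, and not only on whether a phenyl ring is present.

Going by these compounds, both steps are bounds, so their full size remains unknown. Also open, on these data alone, is where a methoxy group or an amine on that phenyl ring would fall, between the number of compound 1 and the limit of compound 3.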